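Compound 4: adding methoxy groups to the aryl ring

A few compounds are considered here, and "the series" means these few. Any claim that something is new, unique, unknown or untested is made for them only; others in the source may bear on it.

Measured so far in a functional assay on MCF7 cells (Homo sapiens) for cytotoxicity, read by MTT assay, with a stated time of 72 h; a higher number here means a weaker inhibitor, a lower number a stronger inhibitor

Compound 1 `O=C(N/N=C/c1ccc(F)cc1)Nc1cc2c(Nc3ccc(F)c(Cl)c3)ncnc2cc1O[C@H]1CCOC1` gives 28200 nM
Compound 2 `N#Cc1ccc(/C=N/NC(=O)Nc2cc3c(Nc4ccc(F)c(Cl)c4)ncnc3cc2O[C@H]2CCOC2)cc1` is recorded as "not determined" (no result reported)
Compound 3 `COc1ccc(/C=N/NC(=O)Nc2cc3c(Nc4ccc(F)c(Cl)c4)ncnc3cc2O[C@H]2CCOC2)cc1` gives 27300 nM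

Compound 3 stands level with compound 1 within the scatter, and compound 2 offers no number for comparison. The next structure is compound 4 `COc1cc(/C=N/NC(=O)Nc2cc3c(Nc4ccc(F)c(Cl)c4)ncnc3cc2O[C@H]2CCOC2)cc(OC)c1OC` and its change from compound 3 is 3,4,5-trimethoxyphenyl in place of 4-methoxyphenyl on a carbon with a double bond to nitrogen with the shared core untouched. Going by the values given here, the only measured step is a 1.0-fold lower number from compound 1 to compound 3 (0.01 log units; within the scatter) and it places methoxy on an aromatic carbon in place of fluoro. Among the compounds with values here, that step lies within the scatter, but it is a single example, and no measured compound carries the 3,4,5-trimethoxyphenyl group. No step beyond the scatter is therefore expected in this assay and no direction is favoured. The expected step is a 1.1-fold lower number from compound 3 to compound 4 (0.02 log units; within the scatter) and this remains a weakly supported estimate. Compound 4 is expected at 26000 nM with an estimated range from 11000 nM to 55000 nM as its upper end.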

Compound 4, half-maximal inhibitory concentration: 26500 nM
Compound 4: middle estimate off by 1.0-fold (0.01 log units), on the low side, and the stated range covers the measured number.
By their numbers in this assay, from the lowest: compounds 4, 3 and 1 (each within the scatter of the next).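

In this assay the swap to 3,4,5-trimethoxyphenyl on the carbon with a double bond to nitrogen gives a 1.0-fold lower number from compound 3 to compound 4 (0.01 log units; within the scatter) and, against the fluorinated analogue, a 1.1-fold lower number from compound 1 to compound 4 (0.03 log units; within the scatter) as well. The earlier step exchanged only one substituent, whereas this one replaces 4-methoxyphenyl (8 heavy atoms, 1 hydrogen-bond acceptor) with a group of 12 heavy atoms and 3 hydrogen-bond acceptors, and the number still stays within the scatter. No measurement at hand explains this flat response.

From the compounds shown here alone, every compound with a number here carries a substituted phenyl ring at this place, so it stays open whether the flat response holds for a ring bearing an amine or a carboxylic acid, or for a longer alkyl chain in place of the ring. Going by these compounds, it also stays open whether any change at this place can move the number beyond the scatter.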